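Oxazolidinedione to thiazolidinedione on the shared core

The compounds below may be only part of what the source reports. "The series", "measured", "known", "first", "only" and "open" are said of these compounds alone.

Compound 1 `CC(C)[C@H](C[C@H]1OC(=O)NC1=O)c1ccc(-c2ccc3cccc(F)c3c2)[nH]c1=O` gives the lowest number of the three measured in an assay on membranes from Chem-1 cells for displacement of a labelled ligand from prostaglandin E2 receptor EP3 subtype (Homo sapiens), read by scintillation counting, with a stated time of 2 h (on this read-out higher numbers stand for weaker inhibition and lower numbers for stronger inhibition), at 6 nM. Compound 2 `CC(C)C(CC1NC(=O)NC1=O)c1ccc(-c2ccc3cccc(F)c3c2)[nH]c1=O` gives 10 nM in this assay, which is within the scatter of compound 1. Among the compounds with values here, compound 3 `CC(C)C(c1ccc(-c2ccc3cccc(F)c3c2)[nH]c1=O)C1C(=O)NC(=O)N1C` gives 46 nM in this assay, a weaker result; the only single-point step, a 4.6-fold higher number from compound 2 to compound 3 (0.66 log units; beyond the scatter), concerns a different exchange and does not bear on the change considered here. Compound 4 `CC(C)[C@H](C[C@H]1SC(=O)NC1=O)c1ccc(-c2ccc3cccc(F)c3c2)[nH]c1=O` differs from compound 1 by 2,4-dioxo-1,3-thiazolidin-5-yl in place of 2,4-dioxo-1,3-oxazolidin-5-yl on a saturated chain carbon, two bonds along the chain from an aromatic carbon. Within the data shown here, no measured step covers this exchange, so the expectation rests on compound 1 alone. In this assay compound 4 is expected near compound 1, estimated at 8 nM (range 3 nM to 25 nM). The expected step of a 1.3-fold higher number from compound 1 to compound 4 (0.12 log units; within the scatter) lies within the scatter.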

Compound 4, inhibition constant in the prostaglandin E2 receptor EP3 subtype assay: 8 nM
Compound 4: the middle estimate sits on the measured number at the digits printed, within the range that was stated.
By their numbers in the prostaglandin E2 receptor EP3 subtype assay, from the lowest: compounds 1, 4 and 2 (each within the scatter of the next); then compound 3.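

In the prostaglandin E2 receptor EP3 subtype assay, 2,4-dioxo-1,3-thiazolidin-5-yl in place of 2,4-dioxo-1,3-oxazolidin-5-yl on this saturated chain carbon gives a 1.3-fold higher number from compound 1 to compound 4 (0.12 log units; within the scatter), so this read-out does not separate the two groups. The same exchange does separate the pair in a physicochemical assay for solubility, measured as kinetic solubility, at pH 2; on this read-out higher numbers stand for higher solubility and lower numbers for lower solubility: the measured solubility of compound 1, 24400 nM, and of compound 4, 4900 nM, a 5.0-fold lower number (0.70 log units; beyond the scatter). In the physicochemical assay compound 1 gives 24400 nM and compound 4 gives 4900 nM.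

As far as these compounds go, whether a carboxylic acid in place of either group at this position would hold the number in the prostaglandin E2 receptor EP3 subtype assay or shift the number in the physicochemical assay remains open.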